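The source may report more compounds than this note shows. Statements on the series, on what has been measured and on what is new or still open speak of the compounds shown alone.

Measured so far in a functional assay on A549 cells (Homo sapiens) for cytotoxicity, read by sulforhodamine B assay; on this read-out lower numbers stand for stronger inhibition and higher numbers for weaker inhibition:
- compound 1 `C=C1[C@@H](OC(C)=O)C[C@@H]2[C@](C)(COC=O)[C@H](OC(C)=O)CC[C@@]2(C)[C@@H]1C[C@@H](Nc1cccc(F)c1)C1=CCOC1=O`: 23200 nM
- compound 2 `C=C1[C@@H](OC(C)=O)C[C@@H]2[C@](C)(CO[Si](C)(C)C(C)(C)C)[C@H](OC(C)=O)CC[C@@]2(C)[C@@H]1C[C@@H](Nc1ccc(F)cc1)C1=CCOC1=O`: 4550 nM
- compound 3 `C=C1[C@@H](OC(C)=O)C[C@@H]2[C@](C)(CO[Si](C)(C)C(C)(C)C)[C@H](OC(C)=O)CC[C@@]2(C)[C@@H]1C[C@@H](Nc1cccc(F)c1)C1=CCOC1=O`: 4060 nM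

Compound 1 gives the highest number of the three. Its nearest neighbour is compound 2, and the gap to compound 3 is a 5.7-fold lower number from compound 1 to compound 3 (0.76 log units; beyond the scatter), which follows the exchange of the group on the oxygen on a saturated carbon. Within the silyl pair, the swap of the fluorophenyl on the amine nitrogen gives a 1.1-fold lower number from compound 2 to compound 3 (0.05 log units; within the scatter), so that change alone leaves the read-out essentially where it was.

Compound 4 `C=C1[C@@H](OC(C)=O)C[C@@H]2[C@](C)(COC=O)[C@H](OC(C)=O)CC[C@@]2(C)[C@@H]1C[C@@H](Nc1ccc(Br)cc1)C1=CCOC1=O` keeps the core and the formyloxy group of compound 1 and differs from it only at the amine nitrogen: 4-bromophenyl in place of 3-fluorophenyl on an amine nitrogen. Among the measured compounds shown here, no measured step introduces a bromine or any group other than fluorine on that phenyl, so the only bearing evidence is the indifference of this assay to the fluorine swap between compound 2 and compound 3. On that basis the expected step is a 1.2-fold lower number from compound 1 to compound 4 (0.06 log units; within the scatter), that is, a number close to that of compound 1 with no clear direction. Compound 4 is therefore estimated at 20000 nM, with a range of 7000 nM to 55000 nM to allow for the untested bromine.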

Compound 4, half-maximal inhibitory concentration: 15900 nM
Beside the measured number, compound 4's estimate is 1.3-fold (0.10 log units) above it; the measured number falls inside the stated range.
By their numbers in this assay, from the lowest: compounds 3 and 2 (each within the scatter of the next); then compounds 4 and 1 (each within the scatter of the next).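

In this assay, exchanging the substituted phenyl on the amine nitrogen gives a 1.5-fold lower number from compound 1 to compound 4 (0.16 log units; within the scatter) in the formyloxy series. The earlier pair, compounds 2 and 3, only moved a fluorine within the silyl series, whereas here the halogen and its printed place change together, and compounds 1 and 4 still cannot be told apart. Across these two pairs, the aryl group on the amine nitrogen has not moved the read-out beyond the scatter, while a 5.7-fold lower number from compound 1 to compound 3 (0.76 log units; beyond the scatter) remains the only listed step beyond it, and nothing available accounts for this insensitivity to the aryl exchange.

Still open, from the compounds shown here alone, is whether the same flat response holds for groups other than halogens on the phenyl, such as methoxy, nitrile or a carboxylic acid, or for a saturated ring such as cyclohexyl in place of the phenyl. Also open, going by these compounds, is whether a free hydroxyl on the oxygen on a saturated carbon sits with the formyloxy compounds or with the silyl compounds in this assay.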